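Swapping the Aryl Group of Compound 2 for 4-Phenylphenyl

The source may hold more compounds than are shown below. What is called first, only, known or untested is meant among the compounds shown, and "the series" means these compounds.

Of the compounds shown here, three built on one shared core have been measured in an assay on microsomes for inhibition of 3-hydroxy-3-methylglutaryl-coenzyme A reductase (Rattus norvegicus); on this read-out lower numbers stand for stronger inhibition and higher numbers for weaker inhibition. Compound 1 `CC(C)=Cc1c(-c2ccccc2)sc(C(C)C)c1/C=C/[C@@H](O)C[C@@H](O)CC(=O)O` gives 1000 nM. Compound 2 `CC(C)c1sc(-c2ccccc2)c(-c2cccc(C(F)(F)F)c2)c1/C=C/[C@@H](O)C[C@@H](O)CC(=O)O` gives 2980 nM, the highest number of the three, with compound 1 nearest and compound 3 furthest from it. Compound 3 `CC(C)c1sc(-c2ccccc2)c(-c2ccc(F)cc2)c1/C=C/[C@@H](O)C[C@@H](O)CC(=O)O` gives 4.4 nM.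

Compound 4 `CC(C)c1sc(-c2ccccc2)c(-c2ccc(-c3ccccc3)cc2)c1/C=C/[C@@H](O)C[C@@H](O)CC(=O)O` awaits measurement in this assay . It differs from compound 2 by 4-phenylphenyl in place of 3-(trifluoromethyl)phenyl on an aromatic carbon. Going by the values given here, two measured steps bear on this change. The replacement of the same group in compound 2 by 4-fluorophenyl gave a 680-fold lower number from compound 2 to compound 3 (2.83 log units; beyond the scatter), and the same 4-fluorophenyl entering in place of 2-methylprop-1-en-1-yl gave a 230-fold lower number from compound 1 to compound 3 (2.36 log units; beyond the scatter), whereas the 3-(trifluoromethyl)phenyl itself gave a 3.0-fold higher number from compound 1 to compound 2 (0.47 log units; beyond the scatter). Among the compounds with values here, compound 4, like compound 3, no longer carries the trifluoromethyl of compound 2, so a step toward a lower number is expected, though no measured compound carries a 4-phenylphenyl and the size of the drop is uncertain. The expected step for compound 4 is a 20-fold lower number from compound 2 to compound 4 (1.30 log units; beyond the scatter). Compound 4 is therefore estimated at 150 nM, with a range from 10 nM to 2000 nM.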

Compound 4, half-maximal inhibitory concentration: > 10000 nM
Compound 4 gave a limit, no number; the forecaster's own chance of this, stated with the estimate: 5%; middle value at least 66-fold (1.82 log units) away from the limit.
By their numbers in this assay, from the lowest: compound 3; then compound 1; then compound 2. At a limit, above all of these: compound 4.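

In this assay compound 4 reaches a limit of the assay and gives no number: the limit of > 10000 nM in this assay, at which 1 of the 4 values shown sits. Phenyl in place of fluoro on the aryl group gave an at least 2200-fold higher number from compound 3 to compound 4 (3.35 log units; beyond the scatter), so one substituent on that ring separates the lowest number of the set from the limit. 4-Phenylphenyl also gave an at least 3.3-fold higher number from compound 2 to compound 4 (0.52 log units; beyond the scatter) and an at least 10-fold higher number from compound 1 to compound 4 (1.00 log units; beyond the scatter), which shows that an aryl group on this aromatic carbon does not by itself bring a low number: of the three aryl groups shown only 4-fluorophenyl does, while compound 2 and compound 4 both go against any such pattern.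

From the compounds shown here alone, how far compound 4 lies beyond its limit stays open, and so does the size of the substituent at which the number begins to climb between fluoro and phenyl. Also open, going by these compounds, is whether a chloro, a methyl or a methoxy in place of that fluoro would stay close to compound 3 or move toward compound 4, and what a plain phenyl on this aromatic carbon would give.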